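Aryl and alkyl substituents on the ring nitrogen of the core

The compounds below may be only part of what the source reports. "The series", "measured", "known", "first", "only" and "open" are said of these compounds alone.

Compound 2 is `CCN1C(=O)/C(=C/N2N=C(c3ccccc3)CC2c2ccccc2O)SC1=S`. In a functional assay on SK-OV-3 cells (Homo sapiens) for antiproliferative activity, read by MTT assay, with a stated time of 72 h (a lower number here means a stronger inhibitor, a higher number a weaker inhibitor), compound 2 reaches only the limit of the assay, > 10000 nM. Compound 1 is `CC(=O)Oc1cccc(N2C(=O)/C(=C/N3N=C(c4ccccc4)CC3c3ccccc3O)SC2=S)c1`, the same core carrying a 3-acetoxyphenyl group on the amide-type nitrogen in the ring. In this assay compound 1 also reaches only the limit, > 10000 nM. The step that the two limits leave unreadable from compound 1 to compound 2 therefore cannot be read in size or direction.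

Compound 3 is `O=C1/C(=C/N2N=C(c3ccccc3)CC2c2ccccc2O)SC(=S)N1c1cccnc1`; it differs from compound 2 by pyridin-3-yl in place of ethyl on an amide-type nitrogen in a ring. Among the measured compounds shown here, the only measured step on this position is the one from compound 1 to compound 2, and since both ends sit at the limit it gives no size. What the data do show is the limit of > 10000 nM in this assay, at which 2 of the 2 values shown sit, so neither an alkyl nor an aryl group on this nitrogen has so far produced a readable number. No step beyond the scatter can be expected in this assay on this basis.

Compound 3 is therefore expected to stay at or around the limit, with an estimated value of 15000 nM (range 5000 nM to 50000 nM), which corresponds to an expected step that the limit leaves unreadable from compound 2 to compound 3.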

Compound 3, half-maximal inhibitory concentration: > 10000 nM
Compound 3 was reported as a limit; the forecaster's own chance of this, stated with the estimate: 80%; the middle value is on the limit's open side.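

In this assay, among the compounds shown here, compound 3 gives > 10000 nM, which is a limit of the assay, so no step from compound 1 or compound 2 to compound 3 can be read in size or direction. The compounds shown leave open whether any group on the amide-type nitrogen gives a readable value, and how ethyl, 3-acetoxyphenyl and pyridin-3-yl rank.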